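Carbamate Substituent Changes and Stability in Phosphate Buffer

The compounds below may be only part of what the source reports. "The series", "measured", "known", "first", "only" and "open" are said of these compounds alone.

In a physicochemical assay, read by HPLC, in phosphate buffer, with a stated time of 2 h, at pH 7.4 (a lower number here means that less of the compound is left, a higher number that more of the compound is left), three compounds have been measured:
Compound 1, `CCCCCOC(=O)N1CCN(C(=O)c2nc(Nc3cc(C4CC4)[nH]n3)c3cc(Cl)ccc3n2)C[C@H]1C`, gives 99.8%.
Compound 2, `CC(C)OC(=O)N1CCN(C(=O)c2nc(Nc3cc(C4CC4)[nH]n3)c3cc(Cl)ccc3n2)C[C@H]1C`, gives 99%.
Compound 3, `C[C@@H]1CN(C(=O)c2nc(Nc3cc(C4CC4)[nH]n3)c3cc(Cl)ccc3n2)CCN1C(=O)OCC(Cl)(Cl)Cl`, gives 98.7%.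

Of the three numbers, that of compound 3 is the lowest, yet only by steps within the scatter: a number 1.1 percentage points lower from compound 1 to compound 3 (within the scatter) and a number 0.3 percentage points lower from compound 2 to compound 3 (within the scatter). Compound 4, `CC(OC(=O)N1CCN(C(=O)c2nc(Nc3cc(C4CC4)[nH]n3)c3cc(Cl)ccc3n2)C[C@H]1C)OC(=O)C(C)(C)C`, differs from compound 3 in one place: 1-(((tert-butyl)carbonyl)oxy)ethyl in place of 2,2,2-trichloroethyl on an oxygen next to a carbonyl group. Among the compounds with values here, the steps that bear on this change are a number 0.8 percentage points lower from compound 1 to compound 2 (within the scatter), a number 1.1 percentage points lower from compound 1 to compound 3 (within the scatter) and a number 0.3 percentage points lower from compound 2 to compound 3 (within the scatter); each alters the group on the same oxygen and none leaves the scatter. Compound 4 is therefore expected to show no step beyond the scatter, a number 2.7 percentage points lower from compound 3 to compound 4 (within the scatter), and its estimated value in this assay is 96%, within a range from 85% to 100%.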

Compound 4, percent of the compound remaining: 90.5%
Compound 4: middle estimate off by 5.5 percentage points, on the high side; the range from low to high includes it.
By their numbers in this assay, from the lowest: compounds 4, 3, 2 and 1 (each within the scatter of the next).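

In this assay, 1-(((tert-butyl)carbonyl)oxy)ethyl, with its 2 hydrogen-bond acceptors, enters on the oxygen next to a carbonyl group and gives a number 8.2 percentage points lower from compound 3 to compound 4 (within the scatter) and a number 8.5 percentage points lower from compound 2 to compound 4 (within the scatter) and a number 9.3 percentage points lower from compound 1 to compound 4 (within the scatter) without any step leaving the scatter. The position thus holds a group of 9 heavy atoms with a double bond outside aromatic rings, and still no difference can be read among the compounds. Nothing at hand explains these numbers. On these data alone, whether a group carrying an amine or a carboxylic acid on this oxygen would give a step beyond the scatter in this assay stays open.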